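This account rests on a few compounds, and the source may have more. Where it says the series, first, only, none or still open, it means among the compounds named here.

Measured compounds:
compound 1 `Cc1c(C2CC2)nc2ncc(-n3ccc(OCc4ccc(Cl)cc4)cc3=O)cn12` — > 1000 nM
compound 2 `Cn1c(C2CC2)nc2ccc(-n3ccc(OCc4ccccc4Cl)cc3=O)cc21` — 160 nM

In an assay on CHO cells for displacement of a labelled ligand from melanin-concentrating hormone receptor 1 (Homo sapiens), read by scintillation counting, with a stated time of 1 h (a lower number here means a stronger inhibitor, a higher number a weaker inhibitor), compound 1 reaches only a limit of the assay, > 1000 nM. Among the compounds with values here, compound 2 gives 160 nM in this assay, and this is the single actual number in the set. The entry for compound 1 is a limit (the limit of > 1000 nM in this assay, at which 1 of the 2 values shown sits). Compound 3, `Cn1c(C2CC2)nc2ccc(-n3ccc(OCc4csc(Cl)c4)cc3=O)cc21`, is not yet measured; it carries 5-chlorothiophen-3-yl in place of 2-chlorophenyl on a saturated chain carbon bound to an oxygen on an aromatic ring. Within the data shown here, no measured pair covers this change, so the expected step of a 1.6-fold higher number from compound 2 to compound 3 (0.19 log units; within the scatter) is small, at most a mild weakening near the scatter. Compound 3 is therefore estimated at 250 nM, within a range of 80 nM to 800 nM.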

Compound 3, half-maximal inhibitory concentration: 14 nM
Compound 3: the middle estimate sits 18-fold (1.25 log units) above what was measured; the whole stated range lies above it.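

In this assay, the group on a saturated chain carbon bound to an oxygen on an aromatic ring proves sensitive to change: 5-chlorothiophen-3-yl in place of 2-chlorophenyl gives an 11-fold lower number from compound 2 to compound 3 (1.06 log units; beyond the scatter). A five-membered aromatic ring with 1 hetero atom is therefore accepted at this place, and it does better than the six-membered carbon ring of compound 2. Nothing at hand gives a cause for this step.

Open, going by these compounds, is whether the gain depends on the chlorine, as an unsubstituted thiophen-3-yl would show. A pyridine ring or a furan ring at this place also remains an open comparison.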